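Benzyloxy to hydroxy on the oxadiazole-indole series

The source may report more compounds than this note shows. Statements on the series, on what has been measured and on what is new or still open speak of the compounds shown alone.

Compound 2 `COc1cc(-c2nnc(-c3c[nH]c4ccccc34)o2)ccc1OCc1ccccc1` shows only a limit in a functional assay on MDA-MB-231 cells (Homo sapiens) for cytotoxicity, read by MTT assay (on this read-out lower numbers stand for stronger inhibition and higher numbers for weaker inhibition), giving > 1000000 nM. Compound 1 `COc1ccc(-c2nnc(-c3c[nH]c4ccccc34)o2)cc1OC` likewise sits at a limit, giving > 1000000 nM. Among the measured compounds shown here, the step from compound 1 to compound 2 is a step that the two limits leave unreadable from compound 1 to compound 2, so it carries no readable size, and the limit of > 1000000 nM in this assay, at which 2 of the 2 values shown sit, means no measured step sets a scale here. Compound 3 `COc1cc(-c2nnc(-c3c[nH]c4ccccc34)o2)ccc1O` differs from compound 2 by hydrogen in place of benzyl on an oxygen on an aromatic ring. With no readable step to lean on, compound 3 is expected to remain near the limit, with an estimated 1000000 nM spanning 200000 nM to 5000000 nM, an expected step of a number no higher from compound 2 to compound 3 (the limit leaves the size open).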

Compound 3, half-maximal inhibitory concentration: > 1000000 nM
Compound 3 gave a limit, no number (the forecaster's own chance of this, stated with the estimate: 70%); the middle value sits exactly at the limit.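

No step can be read among compound 1, compound 2 and compound 3, since all three give only a limit: the limit of > 1000000 nM in this assay, at which 3 of the 3 values shown sit. The compounds shown leave open whether any change on the shared core moves potency at all.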